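The source may hold more compounds than are shown below. What is called first, only, known or untested is meant among the compounds shown, and "the series" means these compounds.

Series notes. Compound 1 `Cc1cccc(Nc2ncnc3c2nnn3Cc2ccccc2)c1` gives 1100 nM in an assay on cell membranes for binding affinity to adenosine receptor A1 (Bos taurus), read by radioligand binding; on this read-out higher numbers stand for weaker inhibition and lower numbers for stronger inhibition. Compound 2 `Cc1cccc(Nc2ncnc3c2nnn3Cc2ccccc2Cl)c1` carries the change chloro in place of hydrogen on an aromatic carbon and gives 5880 nM in this assay, the step being a 5.3-fold higher number from compound 1 to compound 2 (0.73 log units; beyond the scatter). Compound 3 `Nc1ccc(CNc2ncnc3c2nnn3Cc2ccccc2)cc1` differs from compound 1 by 4-aminobenzyl in place of 3-methylphenyl on a nitrogen on an aromatic ring; in this assay compound 3 gives 9500 nM, a step of an 8.6-fold higher number from compound 1 to compound 3 (0.94 log units; beyond the scatter). The values of compound 2 and compound 3 lie within the scatter of each other.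

Compound 4 `Nc1ccc(CNc2ncnc3c2nnn3Cc2ccccc2Cl)cc1` is not yet measured. It differs from compound 3 by chloro in place of hydrogen on an aromatic carbon, the same change as from compound 1 to compound 2, on the same kind of place; the two cores differ by 4-aminobenzyl in place of 3-methylphenyl on a nitrogen on an aromatic ring.

Among the compounds with values here, the expected step is a 4.2-fold higher number from compound 3 to compound 4 (0.62 log units; beyond the scatter), resting on the measured step of a 5.3-fold higher number from compound 1 to compound 2 (0.73 log units; beyond the scatter) carried over to compound 3 with its value 9500 nM, with the single precedent allowing a wide range. Compound 4 is estimated at 40000 nM, between 12000 nM and 120000 nM.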

Compound 4, inhibition constant: > 1000 nM
Compound 4: a limit, no number; the forecaster's own chance of this, stated with the estimate: 20%; the middle value lies beyond the limit too.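

In this assay compound 4 gives > 1000 nM, which is a limit and not a number. Within the data shown here, no step from compound 2 or compound 3 to compound 4 can be read. Going by these compounds, whether chloro in place of hydrogen raises the number with 4-aminobenzyl on the nitrogen, as it does with 3-methylphenyl, stays open.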